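The source may hold more compounds than are shown below. What is called first, only, known or untested is meant among the compounds shown, and "the series" means these compounds.

Of the compounds shown here, three have numbers so far in a physicochemical assay for solubility, using the shake flask method, in phosphate buffer, at pH 7; a lower number here means a less soluble compound, a higher number a more soluble compound. Compound 1 `Cc1cc(C(=O)O)ccc1-c1ccc(Cl)c(-c2ccc(C(F)(F)F)cc2CN2C(=O)O[C@H](c3cc(C(F)(F)F)cc(C(F)(F)F)c3)[C@@H]2C)c1` gives 43000 nM, and compound 3 `COc1ccc(-c2ccc(C(=O)O)cc2C)cc1-c1ccc(C(F)(F)F)nc1CN1C(=O)O[C@H](c2cc(C(F)(F)F)cc(C(F)(F)F)c2)[C@@H]1C` gives 29000 nM. Compound 2 `COc1ccc(-c2ccc(C(=O)O)cc2C)cc1-c1cnc(C(F)(F)F)nc1CN1C(=O)O[C@H](c2cc(C(F)(F)F)cc(C(F)(F)F)c2)[C@@H]1C` gives 6000 nM, the lowest of the three, with both gaps beyond the scatter. Compound 4 `COc1ncc(-c2cc(-c3ccc(C(=O)O)cc3C)ccc2OC)c(CN2C(=O)O[C@H](c3cc(C(F)(F)F)cc(C(F)(F)F)c3)[C@@H]2C)n1` is still unmeasured. It departs from compound 2 by one change, methoxy in place of trifluoromethyl on an aromatic carbon, between two ring nitrogen atoms. Among the measured compounds shown here, no measured pair shows this change alone, so the expectation is loose. A small upward step in this assay is expected, a 1.7-fold higher number from compound 2 to compound 4 (0.22 log units; within the scatter), near the edge of the scatter. The estimate for compound 4 is 10000 nM, with an expected range of 3500 nM to 30000 nM.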

Compound 4, solubility: 52000 nM
For compound 4 the middle estimate is 5.2-fold (0.72 log units) below the measured one; the measured number lies above the stated range.
By their numbers in this assay, from the lowest: compound 2; then compounds 3, 1 and 4 (each within the scatter of the next).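

In this assay, among the compounds shown here, methoxy in place of trifluoromethyl on an aromatic carbon, between two ring nitrogen atoms, gives an 8.7-fold higher number from compound 2 to compound 4 (0.94 log units; beyond the scatter) as the first step that isolates a single change. The step lies beyond the scatter, so the read-out at this position responds clearly to this change. Nothing available explains the size or direction of this step.

This remains a single pair, and whether the step carries over to another core is open. An amine or a nitrile at this position would show whether the higher number is specific to methoxy.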